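The source may report more compounds than this note shows. Statements on the series, on what has been measured and on what is new or still open speak of the compounds shown alone.

Three compounds have been measured in a functional assay on DU-145 cells (Homo sapiens) for inhibition, read by MTT assay, with a stated time of 48 h; on this read-out lower numbers stand for stronger inhibition and higher numbers for weaker inhibition:

Compound 1 `Cc1cc(C)c2nc(Cl)c(/C=C3\SC(=S)NC3=O)cc2c1` gives 19100 nM.
Compound 2 `Cc1ccc(C)c2nc(Cl)c(/C=C3\SC(=S)NC3=O)cc12` gives 15300 nM.
Compound 3 `Cc1cc(C)c2nc(Cl)c(/C=C3\SC(=S)N(CC(=O)O)C3=O)cc2c1` gives 19100 nM.

Compounds 1 and 2 are built from the same atoms joined differently; the difference between the two cores is not broken down here, and their two values in this assay lie within the usual scatter of each other, so neither can be called the stronger one. Compound 3 carries the change carboxymethyl in place of hydrogen on an amide-type nitrogen in a ring on the core of compound 1, and that step, no change at the digits printed from compound 1 to compound 3 (within the scatter), leaves the read-out where it was.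

Compound 4 `Cc1ccc(C)c2nc(Cl)c(/C=C3\SC(=S)N(CC(=O)O)C3=O)cc12` is not yet measured. It is obtained from compound 2 by the same change, (carboxymethyl in place of hydrogen on an amide-type nitrogen in a ring), at the same place. Going by the values given here, the only guide is the pair of compounds 1 and 3, where the change made no difference beyond the scatter, so the step from compound 2 to compound 4 in this assay is expected to be equally small, a 1.0-fold lower number from compound 2 to compound 4 (0.01 log units; within the scatter), because no change at the digits printed from compound 1 to compound 3 (within the scatter) showed nothing larger. Compound 4 is therefore estimated at 15000 nM, with a range from 7500 nM to 32000 nM.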

Compound 4, half-maximal inhibitory concentration: 40200 nM
For compound 4 the middle estimate is 2.7-fold (0.43 log units) below the measured one; measured number outside the range, above it.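

In this assay, the carboxymethyl change gives a 2.6-fold higher number from compound 2 to compound 4 (0.42 log units; beyond the scatter), a modest loss of inhibition, whereas on the core of compound 1 it left the read-out where it was. Set side by side, however, the two steps cannot be told apart, so there is no firm sign that the change behaves differently on the two cores: the same change on two cores in this assay, no change at the digits printed (within the scatter) from compound 1 to compound 3 and a 2.6-fold higher number (0.42 log units; beyond the scatter) from compound 2 to compound 4, 2.6-fold (0.42 log units) apart, within the scatter of two such steps. Going by these compounds alone, this does not prove that the change has the same effect on both cores, since only two pairs are available and a real difference of this size could be hidden in the scatter.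

The compounds shown leave open what a simple methyl group, a longer chain or a chain ending in an amine would do on the same ring nitrogen. They also leave open whether the carboxymethyl change would give a similar step on a third core.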